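Swapping the Amide of Compound 2 for a Carbamate

The source may hold more compounds than are shown below. What is called first, only, known or untested is meant among the compounds shown, and "the series" means these compounds.

Of the compounds shown here, two have so far been measured in an assay on CHO-K1 cells for displacement of a labelled ligand from prostaglandin E2 receptor EP1 subtype (Homo sapiens); a lower number here means a stronger inhibitor, a higher number a weaker inhibitor. Compound 1 `CNC(=O)c1cc(C)n(Cc2cc(Cl)ccc2OCc2ccccc2)n1` gives 100 nM in this assay. Compound 2 `Cc1cc(C(=O)NN2CCOCC2)nn1Cc1cc(Cl)ccc1OCC(C)C` gives 251 nM in this assay, the higher of the two numbers; its nearest neighbour, compound 1, sits a step below it that goes beyond the usual scatter. The two measured compounds differ from each other in more than one place, so no single-change step can be read off between them.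

The next compound, compound 3 `Cc1cc(NC(=O)OC(C)(C)C)nn1Cc1cc(Cl)ccc1OCC(C)C`, differs from compound 2 in one place: (tert-butoxycarbonyl)amino in place of (morpholin-4-yl)carbamoyl on an aromatic carbon. Among the measured compounds shown here, the measured compounds offer no example of this exchange, so its effect is unknown from the data; the counted difference shows that one hydrogen-bond donor is kept while the ring and one hydrogen-bond acceptor are lost. Compound 3 is therefore expected to give a value near 400 nM in this assay. The step of a 1.6-fold higher number from compound 2 to compound 3 (0.20 log units; within the scatter) is expected to be modest, toward a higher number, and close to the edge of the usual scatter. Four of five repeat measurements of compound 3 are estimated to fall between 120 nM and 1300 nM.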

Compound 3, half-maximal inhibitory concentration: 31.6 nM
Estimate against measurement, compound 3: 13-fold (1.10 log units) above, outside the stated range (below it).
By their numbers in this assay, from the lowest: compound 3; then compound 1; then compound 2.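

In this assay, placing (tert-butoxycarbonyl)amino in place of (morpholin-4-yl)carbamoyl on this aromatic carbon of the five-membered ring gives a 7.9-fold lower number from compound 2 to compound 3 (0.90 log units; beyond the scatter). Among the compounds shown here, this is the first single-change step at this position, and it shows that the number here responds to the group carried on this carbon and that the morpholine ring is not needed for a low number in this pair. The atom attached to the ring also changes, from the carbonyl carbon of the amide to the nitrogen of the carbamate, while the hydrogen-bond donor count stays the same, yet nothing shown says why the number falls.

This one exchange alters several things together, so the compounds shown leave open whether the lower number belongs to the tert-butyl group, to the carbamate oxygen or to the nitrogen attachment, which a methyl carbamate, a pivalamide or a free amine on the same carbon could begin to separate. On these data alone, it also remains open whether the exchange would give a step of similar size with the benzyl ether of compound 1 on the shared core.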